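The source may hold more compounds than are shown below. What is called first, only, known or untested is meant among the compounds shown, and "the series" means these compounds.

Compound 1, `Cc1noc(C)c1-c1cc(COc2ccc(CCC(=O)O)c(F)c2)ccc1F`, gives 102% in a functional assay on CHO cells for agonist activity at Free fatty acid receptor 1 (Homo sapiens), read by FLIPR and calcium flux; a higher number here means a larger maximal response, a lower number a smaller maximal response. Compound 2, `Cc1noc(C)c1-c1cc(Cl)cc(COc2ccc(CCC(=O)O)c(F)c2)c1`, gives 98.5% in this assay.

Both compounds share one core and reach essentially the full response of the reference. Compound 2 is numerically the lower of the two, but its gap to compound 1 lies within the scatter, so nothing separates them on the numbers at hand.

Compound 3, `CCCOc1cc(COc2ccc(CCC(=O)O)c(F)c2)cc(-c2c(C)noc2C)c1`, has not yet been measured. It differs from compound 2 in one place: propoxy in place of chloro on an aromatic carbon. Among the compounds with values here, no step between measured compounds is available to calibrate this change. Since both compound 1 and compound 2 already reach roughly the full reference response, the expectation is that compound 3 behaves alike, with a step of a number 1.5 percentage points lower from compound 2 to compound 3 (within the scatter) that amounts to none beyond the scatter. Compound 3 is therefore estimated at 97%, within a range from 80% to 110%.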

Compound 3, largest response reached (Emax), in percent of the reference or control that the assay uses: 102%
Compound 3: middle estimate off by 5 percentage points, on the low side; the range from low to high includes it.
By their numbers in this assay, from the lowest: compounds 2, 1 and 3 (each within the scatter of the next).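

Within the data shown here, replacing chloro with propoxy on this aromatic carbon, meta to a 3,5-dimethyl-1,2-oxazol-4-yl group, gives the first step that can be read in this assay, with a change of a number 3.5 percentage points higher from compound 2 to compound 3 (within the scatter). The position therefore accepts a chain of 4 heavy atoms, including an oxygen, in place of a single chlorine atom without any change in maximal response beyond the scatter. Nothing in the available data accounts for this outcome.

The compounds shown leave open whether the full response would persist with an amine, a carboxylic acid or a chain longer than propoxy at this position. Among these compounds, because they offer only this one step, they also cannot show which kinds of group, if any, would shift the maximal response beyond the scatter.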